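A few compounds are considered here, and "the series" means these few. Any claim that something is new, unique, unknown or untested is made for them only; others in the source may bear on it.

Measured compounds in a functional assay on PC-3 cells (Homo sapiens) for inhibition, read by MTT assay, with a stated time of 48 h; on this read-out higher numbers stand for weaker inhibition and lower numbers for stronger inhibition:

- compound 1 `COc1ccc(-c2coc3cc(OCCCSC(=S)N4CCOCC4)ccc3c2=O)cc1` gives 27400 nM
- compound 2 `COc1ccc(-c2coc3cc(OCCCCCBr)ccc3c2=O)cc1` gives 44800 nM
- compound 3 `COc1ccc(-c2coc3cc(OCCCSC(=S)N4CCN(C(=O)OC(C)(C)C)CC4)ccc3c2=O)cc1` gives 1970 nM

Compound 3 stands lowest of the three numbers in this assay, compound 1 being its nearest neighbour and compound 2 the furthest, both beyond the scatter.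

Among the measured compounds shown here, the one counted step, a 1.6-fold higher number from compound 1 to compound 2 (0.21 log units; within the scatter), concerns a change three bonds along the chain from an oxygen on an aromatic ring and stays within the scatter; it does not touch the amine nitrogen of the six-membered ring and so does not bear on the present step.

Compound 4 `COc1ccc(-c2coc3cc(OCCCSC(=S)N4CCN(C)CC4)ccc3c2=O)cc1` differs from compound 3 by methyl in place of tert-butoxycarbonyl on an amine nitrogen in a ring. For the measured compounds named here, no measured step changes a group on an amine nitrogen in a ring. Going by the values given here, the only related reading is that compound 1, carrying a ring with one nitrogen and one oxygen at the same end of the chain, sits well above compound 3. The step is therefore open; a moderate rise in the number toward compound 1 is taken as plausible but not established.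

Compound 4 is estimated at 5000 nM (range 1500 nM to 20000 nM), which means an expected step of a 2.5-fold higher number from compound 3 to compound 4 (0.40 log units; beyond the scatter).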

Compound 4, half-maximal inhibitory concentration: 2210 nM
The estimate for compound 4 lay 2.3-fold (0.35 log units) above the measured number; the measured number falls inside the stated range.
By their numbers in this assay, from the lowest: compounds 3 and 4 (each within the scatter of the next); then compounds 1 and 2 (each within the scatter of the next).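

In this assay, the group on the amine nitrogen in the ring carries little weight so far: methyl in place of tert-butoxycarbonyl gives a 1.1-fold higher number from compound 3 to compound 4 (0.05 log units; within the scatter), so the much smaller group keeps the number of compound 3 within the scatter. The large difference lies instead with the ring itself, as 4-methylpiperazin-1-yl in place of morpholin-4-yl on the thiocarbonyl carbon gives a 12-fold lower number from compound 1 to compound 4 (1.09 log units; beyond the scatter), and the full end group of compound 4 set against the bromine-ended chain gives a 20-fold lower number from compound 2 to compound 4 (1.31 log units; beyond the scatter). No supporting evidence bears on why these steps take this size.

Open, going by these compounds, is whether that ring nitrogen tolerates other groups, such as a bare hydrogen, a benzyl or a chain ending in a carboxylic acid. Also open, on these data alone, is whether a piperidine ring, with carbon in place of that nitrogen, holds the low number.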